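The source may report more compounds than this note shows. Statements on the series, on what has been measured and on what is new or still open speak of the compounds shown alone.

In an ADME assay on the whole organism for pharmacokinetics, with Rattus norvegicus as the target, at a dose of 1 mg/kg by the intravenous route (on this read-out higher numbers stand for fast clearance and lower numbers for slow clearance), compound 1 `Cc1cccc2ccc(N3CCC(C(=O)N[C@H]4CCC[C@H]4CCc4ccccc4C(=O)O)CC3)nc12` gives 31 mL/min/kg. This is the lower of the two numbers available, since compound 2 `O=C(O)c1ccc(Cl)cc1NC[C@@H]1CCC[C@@H]1NC(=O)C1CCN(c2ccccc2)CC1` gives 81 mL/min/kg, and the gap between them lies beyond the usual scatter. These two compounds differ in more than one place, so no single structural change can be read from their numbers.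

Compound 3 `O=C(O)c1ccccc1CC[C@@H]1CCC[C@@H]1NC(=O)C1CCN(c2ccc(C(F)(F)F)cc2)CC1` departs from compound 1 in just one place: 4-(trifluoromethyl)phenyl in place of 8-methylquinolin-2-yl on an amine nitrogen in a ring. In words, 4-(trifluoromethyl)phenyl stands in place of 8-methylquinolin-2-yl on an amine nitrogen in a ring. Among the measured compounds shown here, no measured pair shows this swap alone, so any forecast is rough. Compound 2, at 81 mL/min/kg, also has one six-membered aromatic ring of carbon only on that amine nitrogen, which offers a weak hint of faster clearance in this assay.

The expected change is a 1.6-fold higher number from compound 1 to compound 3 (0.21 log units; within the scatter), an estimated rise small enough to stay within the usual scatter. For compound 3 the estimated clearance is 50 mL/min/kg, with an expected range from 22 mL/min/kg to 100 mL/min/kg.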

Compound 3, clearance: 5 mL/min/kg
The estimate for compound 3 lay 10-fold (1.00 log units) above the measured number; the whole stated range lies above it.
By their numbers in this assay, from the lowest: compound 3; then compound 1; then compound 2.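

In this assay, among the compounds shown here, this is the first comparison that changes only the group on the amine nitrogen in the ring, and the swap gives a 6.2-fold lower number from compound 1 to compound 3 (0.79 log units; beyond the scatter), so this one place alone can shift clearance beyond the usual scatter while the rest of compound 1 stays the same. The group that enters has one six-membered aromatic ring of carbon only, whereas the group that leaves also has one with 1 hetero atom, and compound 3 at 5 mL/min/kg shows that a carbon-only aromatic ring on this nitrogen can go with slow clearance. Nothing measured here explains why the number falls.

The swap removes the second aromatic ring, its ring nitrogen and the methyl group, and adds the trifluoromethyl group all at once, so the compounds shown cannot tell which of these parts accounts for the step. Groups such as quinolin-2-yl without the methyl, or 4-methylphenyl, would help separate these parts, and it also remains open whether the same swap would give a similar step on a different core.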